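The source may report more compounds than this note shows. Statements on the series, on what has been measured and on what is new or still open speak of the compounds shown alone.

Measured compounds:
Compound 1, `NCCCCc1c[nH]c2c(F)cccc12`, in an assay on isolated protein for inhibition of Myeloperoxidase (Homo sapiens), read by ELISA, with a stated time of 5 min; on this read-out lower numbers stand for stronger inhibition and higher numbers for weaker inhibition: compound 1 gives 21 nM.
Compound 2, `NCC(N)CCc1c[nH]c2ccc(F)cc12`, in this assay: compound 2 gives 26 nM.

On these two numbers compound 2 stands highest, but its nearest neighbour, compound 1, lies only a small way below it, and that gap is within the scatter of the measurement, so the two compounds cannot be ordered against each other.

Compound 3, `CCSCCc1c[nH]c2ccc(F)cc12`, has not yet been measured. It differs from compound 2 in one place: ethylsulfanyl in place of 1,2-diaminoethyl on a saturated chain carbon, two bonds along the chain from an aromatic carbon. The two diamines that leave are replaced by a single sulfur-bearing chain with no hydrogen-bond donors. Among the compounds with values here, no step between measured compounds shows how this assay answers such a change, so the expectation rests on the structural change alone. A step in the weaker direction, of moderate size and beyond the scatter, is expected, that is a 5.8-fold higher number from compound 2 to compound 3 (0.76 log units; beyond the scatter). Compound 3 is therefore estimated at 150 nM, with a range from 35 nM to 700 nM.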

Compound 3, half-maximal inhibitory concentration: > 100 nM
Compound 3: no number, only a limit; the forecaster's own chance of this, stated with the estimate: 5%; the middle value is on the limit's open side.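

In this assay compound 3 gives no number, only a limit of the assay: the limit of > 100 nM in this assay, at which 1 of the 3 values shown sits.

Even so, the change can be read in one direction: ethylsulfanyl in place of 1,2-diaminoethyl gives an at least 3.8-fold higher number from compound 2 to compound 3 (0.58 log units; beyond the scatter), a step beyond the scatter towards weaker inhibition. This is the first step at this position among the compounds shown, and it shows that the position is not indifferent to the group it carries.

As far as these compounds go, how far compound 3 lies past its limit remains open, so the full size of the step is unknown. Also open, from the compounds shown here alone, is which part of the change matters: the loss of the amines or the arrival of the sulfur, a question that a single primary amine on the chain or a plain alkyl chain in the same place would bear on.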